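The compounds below may be only part of what the source reports. "The series", "measured", "known", "first", "only" and "open" are said of these compounds alone.

Compound 1 `O=C(CSc1nnc(-c2ccncc2)o1)N/N=C/c1ccc(O)cc1` gives 158000 nM in an ADME assay on NIH3T3 cells (Mus musculus) for cytotoxicity, read by MTT assay, with a stated time of 24 h; a higher number here means a weaker inhibitor, a lower number a stronger inhibitor.
Compound 2 `COc1ccc(/C=N/NC(=O)CSc2nnc(-c3ccncc3)o2)cc1` gives 132000 nM in this assay.
Compound 3 `O=C(CSc1nnc(-c2ccncc2)o1)N/N=C/c1ccc(O)c(O)c1` gives 154000 nM in this assay.

The three measured compounds share one core and differ only in the substitution of the aryl ring on the carbon with a double bond to nitrogen. All three values lie within the scatter of one another: a 1.2-fold lower number from compound 1 to compound 2 (0.08 log units; within the scatter), a 1.0-fold lower number from compound 1 to compound 3 (0.01 log units; within the scatter) and a 1.2-fold higher number from compound 2 to compound 3 (0.07 log units; within the scatter). No ordering among compounds 1, 2 and 3 can be read from these numbers.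

Compound 4 `COc1cc(/C=N/NC(=O)CSc2nnc(-c3ccncc3)o2)ccc1O` is not yet measured. It differs from compound 3 by methyl in place of hydrogen on an oxygen on an aromatic ring. The same change is made from compound 1 to compound 2, (methyl in place of hydrogen on an oxygen on an aromatic ring), where it gave a 1.2-fold lower number from compound 1 to compound 2 (0.08 log units; within the scatter). The place of the change is described in the same words for both pairs, so it is the same change. The two cores on which it is made differ by hydroxy in place of hydrogen on an aromatic carbon.

For compound 4 the expected step is a 1.1-fold lower number from compound 3 to compound 4 (0.06 log units; within the scatter), placed beside a 1.2-fold lower number from compound 1 to compound 2 (0.08 log units; within the scatter); this rests on the one measured occurrence of the change, which stayed within the scatter, and on the fact that compound 3 and compound 1 themselves sit within the scatter of each other. Compound 4 is therefore estimated at 135000 nM in this assay, with a likely range from 80000 nM to 230000 nM.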

Compound 4, half-maximal inhibitory concentration: 148000 nM
Estimate against measurement, compound 4: 1.1-fold (0.04 log units) below; measured number inside the range.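

In this assay, methyl in place of hydrogen on an oxygen on an aromatic ring gives a 1.0-fold lower number from compound 3 to compound 4 (0.02 log units; within the scatter), and the other two new comparisons, a 1.1-fold higher number from compound 2 to compound 4 (0.05 log units; within the scatter) and a 1.1-fold lower number from compound 1 to compound 4 (0.03 log units; within the scatter), also stay within the scatter. Carried from the core of compound 1 to the core of compound 3, the change gives steps that do not differ: the same change on two cores in this assay, a 1.2-fold lower number (0.08 log units; within the scatter) from compound 1 to compound 2 and a 1.0-fold lower number (0.02 log units; within the scatter) from compound 3 to compound 4, 1.2-fold (0.06 log units) apart, within the scatter of two such steps. This shows that on these two cores the change leaves the number within the scatter, but with neither step separable from that scatter it does not show a real effect that transfers from one core to the other, and two cores say nothing about how the change would behave on a core where the step is larger.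

The compounds shown carry only hydroxy and methoxy on the aryl ring, so it remains open whether an amine, a carboxylic acid or a longer chain such as butoxy in place of methoxy would move the number beyond the scatter. Going by these compounds, it also remains open whether the four compounds would stay this close in any read-out other than this assay.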